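Swapping an Aromatic Ring for a Dihydropyran Ring

The compounds below may be only part of what the source reports. "The series", "measured", "known", "first", "only" and "open" are said of these compounds alone.

Compound 1, `Cc1cc(NCc2ccccn2)n2ncc(-c3ccc(F)cc3)c2n1`, was tested in a physicochemical assay for solubility, read by HPLC, using the shake flask method, measured as kinetic solubility, with a stated time of 2 h, at pH 7.4; on this read-out lower numbers stand for lower solubility and higher numbers for higher solubility. In this assay compound 1 gives < 5000 nM, which is a limit of the assay rather than a number. Two other compounds share its core. Compound 2, `Cc1cc(NCc2cnccn2)n2nc(C)c(-c3ccccc3)c2n1`, gives 7100 nM. Compound 3, `Cc1cc(NCc2ncc[nH]2)n2nc(C)c(-c3ccccc3)c2n1`, gives < 5000 nM, again a limit. Among the measured compounds shown here, the one measured step, an at least 1.4-fold lower number from compound 2 to compound 3 (0.15 log units; that floor lies within the scatter), changes a different part of the molecule, and the limit of < 5000 nM in this assay, at which 2 of the 3 values shown sit, shows how often this floor appears. Compound 4, `Cc1cc(NCc2ccccn2)n2ncc(C3=CCOCC3)c2n1`, differs from compound 1 by a group of 6 heavy atoms (5 carbon, 1 oxygen; one six-membered non-aromatic ring with 1 hetero atom) in place of a group of 7 heavy atoms (6 carbon, 1 fluorine; one six-membered aromatic ring of carbon only), on an aromatic carbon. For the measured compounds named here, no measured step bears on that change, so the expectation rests on the change alone and carries wide uncertainty. For compound 4 the number is expected to be 8000 nM, with a range of 3000 nM to 25000 nM. That estimate means an expected step of an at least 1.6-fold higher number from compound 1 to compound 4 (0.20 log units; that floor lies within the scatter).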

Compound 4, solubility: 171000 nM
Compound 4: the middle estimate sits 21-fold (1.33 log units) below what was measured; measured number outside the range, above it.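

Putting the six-membered non-aromatic ring with its oxygen in place of 4-fluorophenyl, on this aromatic carbon, gives an at least 34-fold higher number from compound 1 to compound 4 (1.53 log units; beyond the scatter), the only step shown at this position and one beyond the scatter. That step is only a floor, because compound 1 sits at a limit of the assay rather than at a number: the limit of < 5000 nM in this assay, at which 2 of the 4 values shown sit.

Which part of the change carries the step stays open: the ring oxygen, the loss of the aromatic ring, or the loss of the fluorine. The compounds shown also leave open how a saturated tetrahydropyran or a piperidine would read at this position.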